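Cyclobutyl to methoxyazetidinyl: expected dog half-life

A few compounds are considered here, and "the series" means these few. Any claim that something is new, unique, unknown or untested is made for them only; others in the source may bear on it.

Measured so far in an ADME assay (Canis lupus familiaris, strain Beagle) for metabolic stability; on this read-out lower numbers stand for a shorter-lived compound and higher numbers for a longer-lived compound:
- compound 1 `CCn1c(-c2cnc(C)nc2)nc2c(N[C@H]3CCN(C(=O)C4CCC4)C3)ncnc21`: 1.3 h
- compound 2 `CCn1c(-c2ccc(C(F)(F)F)nc2)nc2c(O[C@H]3CCN(C(=O)N4CC(OC)C4)C3)ncnc21`: 0.7 h
- compound 3 `CCn1c(-c2ccc(C(F)(F)F)nc2)nc2c(O[C@H]3CCN(C(=O)[C@H]4C[C@@H](OC)C4)C3)ncnc21`: 2.6 h

Compound 1 has the second highest of the three numbers; its gap to compound 2 and its gap to compound 3 both lie within the usual scatter, so no order among the three can be claimed from these values.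

Compound 4 `CCn1c(-c2cnc(C)nc2)nc2c(N[C@H]3CCN(C(=O)N4CC(OC)C4)C3)ncnc21` has not yet been measured. It differs from compound 1 in one place: 3-methoxyazetidin-1-yl in place of cyclobutyl on a carbonyl carbon

Going by the values given here, only one measured step touches this kind of change: a 3.7-fold higher number from compound 2 to compound 3 (0.57 log units; beyond the scatter), a modest, trustworthy rise when the azetidine was swapped for a carbon ring. The change from compound 1 to compound 4 runs the opposite way, carbon ring out and azetidine in, though the entering ring there carried a methoxy group and the surrounding core differs. A modest drop is therefore expected, a 2.2-fold lower number from compound 1 to compound 4 (0.34 log units; beyond the scatter), and compound 4 is estimated at 0.6 h, most likely between 0.3 h and 1.4 h.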

Compound 4, half-life: 1.7 h
Compound 4: middle estimate off by 2.8-fold (0.45 log units), on the low side; measured number outside the range, above it.
By their numbers in this assay, from the lowest: compounds 2, 1, 4 and 3 (each within the scatter of the next, the first and the last beyond it).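

In this assay, exchanging cyclobutyl for 3-methoxyazetidin-1-yl on the carbonyl carbon gives a 1.3-fold higher number from compound 1 to compound 4 (0.12 log units; within the scatter) on the core of compound 1, so this exchange leaves no readable difference in half-life here. The earlier azetidine step, a 3.7-fold higher number from compound 2 to compound 3 (0.57 log units; beyond the scatter) on another core, lay beyond the scatter, but its incoming carbon ring also carried a methoxy group, and the present result shows that its size does not carry over to this pair. Nothing available explains the contrast between the two steps.

Still open, on these data alone, is whether the ring nitrogen and the methoxy group each matter on their own or merely offset each other on the core of compound 1. A plain azetidin-1-yl or a 3-methoxycyclobutyl at this carbonyl carbon on that core would help separate the two.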